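Three Amides Measured, a Dimethylphenyl Analogue Awaiting Its Number

The source may hold more compounds than are shown below. What is called first, only, known or untested is meant among the compounds shown, and "the series" means these compounds.

Compound 1, `O=C(Nc1cc(-c2ccccc2)nn1-c1ccccc1)c1cccc(C(F)(F)F)c1`, gives 228 nM in a functional assay on cells for positive allosteric modulation of metabotropic glutamate receptor 5 (Rattus norvegicus), read by calcium flux; a lower number here means that less compound is needed, a higher number that more compound is needed for the effect.
Compound 2, `O=C(Nc1cc(-c2ccccc2)nn1-c1ccccc1)c1cccc([N+](=O)[O-])c1`, gives 39 nM in this assay.
Compound 3, `O=C(Nc1cc(-c2ccccc2)nn1-c1ccccc1)c1ccc(C(F)(F)F)cc1`, gives 38 nM in this assay.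

Compound 1 stands at the highest number of the three measured compounds, and both of the others lie beyond the scatter below it: a 5.8-fold lower number from compound 1 to compound 2 (0.77 log units; beyond the scatter) and a 6.0-fold lower number from compound 1 to compound 3 (0.78 log units; beyond the scatter). Compound 2 and compound 3 sit within the scatter of each other, as a 1.0-fold lower number from compound 2 to compound 3 (0.01 log units; within the scatter) shows.

Compound 4, `Cc1ccc(C(=O)Nc2cc(-c3ccccc3)nn2-c2ccccc2)cc1C`, has not yet been measured. It differs from compound 1 in one place: 3,4-dimethylphenyl in place of 3-(trifluoromethyl)phenyl on a carbonyl carbon. Within the data shown here, no measured step exchanges a trifluoromethyl for a methyl pair, so neither step bears on this change directly. What the measured steps do show is that the two departures from the 3-(trifluoromethyl)phenyl of compound 1 each gave a modest drop in the number. Taken as a loose indication that compound 1 is the weakest arrangement seen so far, a modest lowering is expected for compound 4 as well, though with a wider uncertainty than the measured steps carry. The estimate for compound 4 is 100 nM, within 30 nM to 400 nM, which would mean a 2.3-fold lower number from compound 1 to compound 4 (0.36 log units; beyond the scatter).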

Compound 4, half-maximal effective concentration: 20 nM
Compound 4: middle estimate off by 5.0-fold (0.70 log units), on the high side; the measured number lies below the stated range.
By their numbers in this assay, from the lowest: compounds 4, 3 and 2 (each within the scatter of the next); then compound 1.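

On the carbonyl carbon, 3,4-dimethylphenyl in place of 3-(trifluoromethyl)phenyl gives a large step (an 11-fold lower number from compound 1 to compound 4 (1.06 log units; beyond the scatter)), where the earlier departures from compound 1 gave modest ones. The other two new steps (a 1.9-fold lower number from compound 3 to compound 4 (0.28 log units; within the scatter); a 2.0-fold lower number from compound 2 to compound 4 (0.29 log units; within the scatter)) lie within the scatter, so an aryl group bearing only methyl groups reads alongside the 4-(trifluoromethyl)phenyl and 3-nitrophenyl groups, and compound 1 alone stands apart among the four. Nothing at hand speaks to the cause of these steps.

On these data alone, it remains open whether one methyl group alone, as in 3-methylphenyl or 4-methylphenyl, would give a number like that of the 3,4-dimethylphenyl group. Also open, as far as these compounds go, is how a methoxy group, an amine or a carboxylic acid on this ring would read in this assay.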